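The source may hold more compounds than are shown below. What is called first, only, known or untested is meant among the compounds shown, and "the series" means these compounds.

In a functional assay on a cell-free system (plasma, Homo sapiens), with a stated time of 3 min (on this read-out higher numbers stand for weaker inhibition and lower numbers for stronger inhibition), compound 1 `O=C(NCc1cc(Cl)ccc1-n1cnnn1)[C@@H]1CC=NN1C(=O)[C@H](O)c1ccccc1` gives 840 nM and compound 2 `O=C(NCc1cc(Cl)ccc1-n1cnnn1)[C@@H]1[C@H]2C[C@H]2CN1C(=O)[C@H](O)c1ccccc1` gives 960 nM on the same read-out, so these two values lie within the scatter of each other. Compound 3 `O=C(NCc1cc(Cl)ccc1-n1cnnn1)[C@@H]1[C@H]2C[C@H]2CN1C(=O)[C@H](O)C1CCCCC1` differs from compound 2 by cyclohexyl in place of phenyl on a saturated chain carbon bound to a carbonyl carbon and an oxygen on a saturated carbon at a saturated chain carbon bound to a carbonyl carbon and an oxygen on a saturated carbon. For the measured compounds named here, no measured pair shows this change, so only a modest move toward stronger inhibition is expected, and the estimated 1.9-fold lower number from compound 2 to compound 3 (0.28 log units; within the scatter) is uncertain. For compound 3 the estimate is 500 nM in this assay with 150 nM to 1500 nM as the expected range.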

Compound 3, half-maximal inhibitory concentration: 850 nM
Compound 3: middle estimate off by 1.7-fold (0.23 log units), on the low side; the measured number falls inside the stated range.
By their numbers in this assay, from the lowest: compounds 1, 3 and 2 (each within the scatter of the next).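

The step of a 1.1-fold lower number from compound 2 to compound 3 (0.05 log units; within the scatter) in this assay shows that, on the saturated chain carbon bound to a carbonyl carbon and an oxygen on a saturated carbon, a cyclohexyl ring can stand in place of phenyl with the numbers remaining within the scatter of each other. The aromatic character of this ring is therefore not required for a number in this range. Nothing available explains this result. The compounds shown leave open how a pyridyl ring, a longer alkyl chain or a smaller methyl group would read at this position.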